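Fluorophenoxy in Place of Fluorophenylsulfanyl on the Shared Core

The source may hold more compounds than are shown below. What is called first, only, known or untested is meant among the compounds shown, and "the series" means these compounds.

Of the compounds shown here, three built on one core have been tested in a functional assay on MDA-MB-435 cells (Homo sapiens) for inhibition, read by sulforhodamine B assay, with a stated time of 48 h; on this read-out lower numbers stand for higher toxicity in this test and higher numbers for lower toxicity in this test. Compound 3 `Nc1cc(N)c2nc(-c3ccccc3)c(Sc3ccc(F)cc3)nc2c1` carries a (4-fluorophenyl)sulfanyl group and in this assay gives 66100 nM, the lowest of the two numbers on hand. Compound 1 `Nc1cc(N)c2nc(-c3ccccc3)c(Oc3ccc(Cl)c(Cl)c3)nc2c1`, bearing 3,4-dichlorophenoxy instead, gives 93300 nM. For compound 2 `CCOC(=O)[C@H](CCC(=O)O)NC(=O)c1ccc(Sc2nc3cc(N)cc(N)c3nc2-c2ccccc2)cc1` only a limit was reported in this assay, < 100000 nM. Going by the values given here, the single measured step, a 1.4-fold lower number from compound 1 to compound 3 (0.15 log units; within the scatter), leaves compound 3 and compound 1 indistinguishable.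

Compound 4 `Nc1cc(N)c2nc(-c3ccccc3)c(Oc3ccc(F)cc3)nc2c1` has not yet been measured. It differs from compound 3 in one place: 4-fluorophenoxy in place of (4-fluorophenyl)sulfanyl on an aromatic carbon. Among the compounds with values here, the only step measured so far replaces the whole 3,4-dichlorophenoxy group with (4-fluorophenyl)sulfanyl, so it is not the same exchange as the one leading to compound 4, and its size in any case stayed within the scatter. With no step beyond the scatter among the numbers shown, there is no ground for expecting a shift in either direction. The step of a 1.2-fold higher number from compound 3 to compound 4 (0.08 log units; within the scatter) is therefore estimated to stay within the scatter. Compound 4 is expected to give about 80000 nM in this assay, most likely between 40000 nM and 150000 nM.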

Compound 4, concentration lethal to 50% of the cells: 67600 nM
Compound 4: the middle estimate sits 1.2-fold (0.07 log units) above what was measured; measured number inside the range.
By their numbers in this assay, from the lowest: compounds 3, 4 and 1 (each within the scatter of the next).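

Going by these compounds alone, compound 3 and compound 4 carry the same 4-fluorophenyl ring and differ only in the atom linking it to the shared core, so this pair gives the first direct look at sulfur against oxygen at this position, next to the ring nitrogen, in this assay: a 1.0-fold higher number from compound 3 to compound 4 (0.01 log units; within the scatter). Compound 1 and compound 4 share the oxygen link and differ only in the ring it carries, which separates the ring from the link in a way the earlier step could not: a 1.4-fold lower number from compound 1 to compound 4 (0.14 log units; within the scatter). Both steps are within the scatter, so among these compounds neither exchanging the linking atom nor replacing 3,4-dichlorophenyl with 4-fluorophenyl gives a difference that can be read.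

Compound 2 has only a limit and not a number, so its place among the others cannot be read: the limit of < 100000 nM in this assay, at which 1 of the 4 values shown sits. Still open, as far as these compounds go, is whether a larger change at this position, such as an amine in place of the oxygen or sulfur link, or a longer chain in place of the aromatic ring, would produce a step beyond the scatter.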